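This account rests on a few compounds, and the source may have more. Where it says the series, first, only, none or still open, it means among the compounds named here.

Of the compounds shown here, three sharing one core have been tested in a functional assay on NCI-H23 cells (Homo sapiens) for antiproliferative activity; a higher number here means a weaker inhibitor of growth, a lower number a stronger inhibitor of growth. Compound 1 `O=C(CCC1=CCN(Cc2ccc(C(F)(F)F)cc2)C1=O)NO` gives 6640 nM in this assay, the highest of the three numbers. Compound 3 `COc1ccccc1CN1CC=C(CCC(=O)NO)C1=O` gives 6130 nM, which lies within the usual scatter of the number for compound 1. Compound 2 `COc1cccc(CN2CC=C(CCC(=O)NO)C2=O)c1` gives 1970 nM, a gap from compound 1 that is beyond the scatter.

Compound 4 `COc1ccc(CN2CC=C(CCC(=O)NO)C2=O)cc1` has not yet been measured. It differs from compound 1 in one way: methoxy in place of trifluoromethyl on an aromatic carbon. For the measured compounds named here, no measured pair shows exactly this change, so its size can only be guessed; a small move toward a lower number, perhaps not beyond the scatter, seems reasonable. Compound 4 is expected to give about 4000 nM in this assay, within a range from 1500 nM to 10000 nM. The expected step is a 1.7-fold lower number from compound 1 to compound 4 (0.22 log units; within the scatter).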

Compound 4, concentration for 50% growth inhibition: 1640 nM
Compound 4: middle estimate off by 2.4-fold (0.39 log units), on the high side; low and high end bracket the measured number.
By their numbers in this assay, from the lowest: compounds 4 and 2 (each within the scatter of the next); then compounds 3 and 1 (each within the scatter of the next).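

Methoxy in place of trifluoromethyl on an aromatic carbon, para to a large group, gives a 4.0-fold lower number from compound 1 to compound 4 (0.61 log units; beyond the scatter) in this assay and this step lies beyond the scatter. For the compounds shown here, it is the first change in one place whose size can be read, and it shows that the group at this position affects the number. No measurement here explains the step. From the compounds shown here alone, whether a hydroxyl group, a chlorine atom or an amine at this position would give a lower or higher number remains open.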